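Adding a second chloro to compound 2

The source may report more compounds than this note shows. Statements on the series, on what has been measured and on what is new or still open speak of the compounds shown alone.

- compound 1 `COc1ccc(-c2nc(C)c(C(=O)CSc3nc(N)c(C#N)c(-c4ccc(Cl)cc4)n3)s2)cc1`: 4540 nM
- compound 2 `COc1ccc(-c2nc(C)c(C(=O)CSc3nc(-c4ccc(Cl)cc4)c(C#N)c(=O)[nH]3)s2)cc1`: 45900 nM
- compound 3 `COc1ccc(-c2nc(SCC(=O)c3sc(-c4ccc(Cl)cc4)nc3C)[nH]c(=O)c2C#N)cc1OC`: 38600 nM

All three values come from a functional assay on U-87MG ATCC cells for antiproliferative activity against U-87 MG (Homo sapiens), read by MTT assay, with a stated time of 48 h; a lower number here means a stronger inhibitor, a higher number a weaker inhibitor. Compound 2 has the highest number of the three at 45900 nM, but compound 3 at 38600 nM lies within the usual scatter of it, so those two cannot be told apart. Compound 1 at 4540 nM has a lower number than compound 2, and that gap lies well beyond the scatter.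

The next compound to be tested is compound 4 `COc1ccc(-c2nc(C)c(C(=O)CSc3nc(-c4ccc(Cl)c(Cl)c4)c(C#N)c(=O)[nH]3)s2)cc1`. It differs from compound 2 by one change, chloro in place of hydrogen on an aromatic carbon, which turns a 4-chlorophenyl into a 3,4-dichlorophenyl.

Within the data shown here, no two measured compounds differ in only one place, so nothing here shows directly what this change does in this assay. The only hint is indirect. Compound 2 and compound 3 differ in more than one place, yet compound 3 at 38600 nM stays within the scatter. A single added chloro is therefore not expected to move the number far. The expected change is a 1.5-fold lower number from compound 2 to compound 4 (0.18 log units; within the scatter), a slight move toward a stronger inhibitor that would stay within the scatter. For compound 4 the estimated value is 30000 nM, with an expected range from 10000 nM to 80000 nM.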

Compound 4, half-maximal inhibitory concentration: 68500 nM
Compound 4: the middle estimate sits 2.3-fold (0.36 log units) below what was measured; low and high end bracket the measured number.
By their numbers in this assay, from the lowest: compound 1; then compounds 3, 2 and 4 (each within the scatter of the next).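

In this assay, the step is a 1.5-fold higher number from compound 2 to compound 4 (0.17 log units; within the scatter). Among these compounds, this is the first direct reading of this change, and it shows that 3,4-dichlorophenyl and 4-chlorophenyl cannot be told apart here: at this place on the ring, ortho to a chloro group, one added chloro brings no readable gain or loss. No measurement is available that could explain this result.

From the compounds shown here alone, what a fluoro, a bromo, a trifluoromethyl or an amine would do at the same place remains open, so this single step cannot show whether the position tolerates other groups or simply this one. Going by these compounds, it is also open whether the same chloro would have as little effect on the core of compound 1, which gives a clearly lower number than compound 2 in this assay.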